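This account rests on a few compounds, and the source may have more. Where it says the series, first, only, none or still open, it means among the compounds named here.

- compound 1 `O=C1C(=Cc2ccc(O)cc2)C(=O)N(c2ccc(Cl)cc2)N1c1ccc(Cl)cc1`: 23200 nM
- compound 2 `COc1cccc(C=C2C(=O)N(c3ccc(Cl)cc3)N(c3ccc(Cl)cc3)C2=O)c1OC`: 11900 nM

These two values come from a functional assay on MCF7 cells (Homo sapiens) for cytotoxicity, read by MTT assay, with a stated time of 72 h; a lower number here means a stronger inhibitor, a higher number a weaker inhibitor. Among the compounds with values here, compound 2 stands level with compound 1, the only other measured compound, as the gap between them lies within the usual scatter. The next compound is compound 3 `O=C1C(=C/C=C/c2ccccc2)C(=O)N(c2ccc(Cl)cc2)N1c1ccc(Cl)cc1`, which has not yet been measured. The change is 2-phenylethenyl in place of 2,3-dimethoxyphenyl on a double-bonded chain carbon bound to a double-bonded ring carbon, and it sits on a double-bonded chain carbon bound to a double-bonded ring carbon.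

Within the data shown here, only one measured step bears on this: a 1.9-fold lower number from compound 1 to compound 2 (0.29 log units; within the scatter). Among the measured compounds shown here, that swap at the same place made no difference beyond the scatter, although no measured compound yet carries 2-phenylethenyl. No clear shift in this assay is therefore expected, only a wide uncertainty. The expected step is a 1.0-fold higher number from compound 2 to compound 3 (0.00 log units; within the scatter). For compound 3 the estimated value is 12000 nM, with an expected range of 4000 nM to 30000 nM.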

Compound 3, half-maximal inhibitory concentration: 9400 nM
The estimate for compound 3 lay 1.3-fold (0.11 log units) above the measured number; the range from low to high includes it.
By their numbers in this assay, from the lowest: compounds 3, 2 and 1 (each within the scatter of the next, the first and the last beyond it).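

In this assay, 2-phenylethenyl can take the place of 2,3-dimethoxyphenyl on the double-bonded chain carbon bound to a double-bonded ring carbon with no change beyond the scatter (a 1.3-fold lower number from compound 2 to compound 3 (0.10 log units; within the scatter)). Within the data shown here, this shows that a group with no hydrogen-bond acceptors can stand here without a loss in this assay, while the comparison with 4-hydroxyphenyl gives the first step at this place to pass the scatter, though only modestly (a 2.5-fold lower number from compound 1 to compound 3 (0.39 log units; beyond the scatter)). Nothing measured here explains this difference.

The compounds shown leave open how a chain longer than 2-phenylethenyl would read at this place. Also open, as far as these compounds go, is what an amine or a carboxylic acid here would do to the number, since all three compounds carry a six-membered aromatic ring at this spot.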